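This account rests on a few compounds, and the source may have more. Where it says the series, first, only, none or still open, it means among the compounds named here.

For the measured compounds named here, compound 1 `CCCCSc1n[nH]c(-n2[se]c3ccccc3c2=O)n1` is the starting point; in a functional assay on A549 cells (Homo sapiens) for antiproliferative activity, read by CCK-8 assay, with a stated time of 48 h (a higher number here means a weaker inhibitor, a lower number a stronger inhibitor), compound 1 gives 12500 nM, the only number among the values shown. Compound 2 `Cc1ccc(CSc2n[nH]c(-n3[se]c4ccccc4c3=O)n2)cc1` is the other measured compound. In this assay compound 2 reports > 50000 nM, which is a limit of the assay and not a number. Going by the values given here, the one measured step, an at least 4.0-fold higher number from compound 1 to compound 2 (0.60 log units; beyond the scatter), exchanges a whole aryl group for a chain. Compound 3 `CCCCCSc1n[nH]c(-n2[se]c3ccccc3c2=O)n1` differs from compound 1 by methyl in place of hydrogen on a saturated chain carbon, four bonds along the chain from a sulfur. Among the compounds with values here, no measured step covers lengthening a chain by one carbon, so that step offers no guide. Compound 3 is therefore expected to sit close to compound 1, with no change at the digits printed from compound 1 to compound 3 (within the scatter) within the scatter, estimated at 12500 nM with a range of 6000 nM to 30000 nM.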

Compound 3, half-maximal inhibitory concentration: 21100 nM
Estimate against measurement, compound 3: 1.7-fold (0.23 log units) below; the range from low to high includes it.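

In this assay, methyl in place of hydrogen on a saturated chain carbon, four bonds along the chain from a sulfur, gives a 1.7-fold higher number from compound 1 to compound 3 (0.23 log units; within the scatter), so this added carbon leaves no change that can be told from scatter. Butyl in place of 4-methylphenyl on a saturated chain carbon bound to a sulfur gives an at least 2.3-fold lower number from compound 2 to compound 3 (0.37 log units; beyond the scatter), so the second chain compound also stands apart from the aryl compound. Compound 2 carries a limit and not a number, so this step has only a bound: the limit of > 50000 nM in this assay, at which 1 of the 3 values shown sits.

From the compounds shown here alone, whether a longer chain, or a chain ending in an amine or a carboxylic acid, would stay at this level remains open.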